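Replacing fluoro with methoxycarbonyl: notes on compound 4

A few compounds are considered here, and "the series" means these few. Any claim that something is new, unique, unknown or untested is made for them only; others in the source may bear on it.

Measured in a functional assay on HepG2 cells (Homo sapiens) for inhibition, read by MTT assay (on this read-out higher numbers stand for weaker inhibition of growth and lower numbers for stronger inhibition of growth), so far:
compound 1 `COc1cc2oc(-c3cccc(NC(=O)c4ccccc4)c3)cc(=O)c2c(OC)c1OC` gives 11700 nM 
compound 2 `COc1cc2oc(-c3cccc(NC(=O)c4cccc(Br)c4)c3)cc(=O)c2c(OC)c1OC` gives 10900 nM 
compound 3 `COc1cc2oc(-c3cccc(NC(=O)c4ccc(F)cc4)c3)cc(=O)c2c(OC)c1OC` gives 47200 nM 

Compound 3 stands highest of the three in this assay and is the weakest inhibitor of growth here, with its steps to both others beyond the scatter. Compound 4 `COC(=O)c1ccc(C(=O)Nc2cccc(-c3cc(=O)c4c(OC)c(OC)c(OC)cc4o3)c2)cc1` carries methoxycarbonyl in place of fluoro on an aromatic carbon, para to a large group: methoxycarbonyl in place of fluoro on an aromatic carbon.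

Adding a fluoro group is the step of a 4.0-fold higher number from compound 1 to compound 3 (0.61 log units; beyond the scatter), and the comparison with bromo is the step of a 4.3-fold higher number from compound 2 to compound 3 (0.64 log units; beyond the scatter). Both are modest. Bromo in place of hydrogen gives a 1.1-fold lower number from compound 1 to compound 2 (0.03 log units; within the scatter), so not every substituent moves the number. For the measured compounds named here, no measured compound carries methoxycarbonyl, so the data do not fix its effect. With fluoro gone, a modest move back towards compound 1 at 11700 nM is expected, though with wide uncertainty. The expected change is a 2.4-fold lower number from compound 3 to compound 4 (0.37 log units; beyond the scatter) in this assay. The estimate for compound 4 is 20000 nM, with an expected range of 8000 nM to 60000 nM.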

Compound 4, concentration for 50% growth inhibition: > 100000 nM
Compound 4: no number, only a limit; the forecaster's own chance of this, stated with the estimate: 8%; at least 5.0-fold (0.69 log units) between middle value and limit.
By their numbers in this assay, from the lowest: compounds 2 and 1 (each within the scatter of the next); then compound 3. At a limit, above all of these: compound 4.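

In this assay compound 4 gives only a limit, > 100000 nM: the limit of > 100000 nM in this assay, at which 1 of the 4 values shown sits.

On the aromatic carbon para to a large group, methoxycarbonyl moves the number further up than fluoro, with an at least 2.1-fold higher number from compound 3 to compound 4 (0.32 log units; beyond the scatter), and in place of hydrogen it gives an at least 8.5-fold higher number from compound 1 to compound 4 (0.93 log units; beyond the scatter). From the bromo compound the step is an at least 9.1-fold higher number from compound 2 to compound 4 (0.96 log units; beyond the scatter), so changes at this position can cost more growth inhibition than the modest steps seen earlier.

From the compounds shown here alone, it stays open whether the rise belongs to methoxycarbonyl itself or to most groups other than hydrogen at this place; a carboxylic acid, a primary amide or a methyl group there would separate these readings. Going by these compounds, how far compound 4 lies past its limit also remains open.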